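This account rests on a few compounds, and the source may have more. Where it says the series, first, only, none or still open, it means among the compounds named here.

Among the measured compounds shown here, compound 2 (`COc1cc(/C=C/c2nnc(NC(=O)c3ccccc3Br)s2)c(Br)c(OC)c1OC`) gives 250 nM in a functional assay on HepG2 cells (Mus musculus) for antiproliferative activity against HepG2 (Homo sapiens), read by MTT assay, with a stated time of 48 h (a lower number here means a stronger inhibitor, a higher number a weaker inhibitor), the upper end of the numbers so far. Compound 1 (`COc1cccc(C(=O)Nc2nnc(/C=C/c3cc(OC)c(OC)c(OC)c3Br)s2)c1`) gives 120 nM, and compound 3 (`COc1cc(/C=C/c2nnc(NC(=O)c3ccc(Cl)cc3)s2)c(Br)c(OC)c1OC`) gives 180 nM. Compound 4 (`COc1cc(/C=C/c2nnc(NC(=O)c3cccc(F)c3)s2)c(Br)c(OC)c1OC`) carries 3-fluorophenyl in place of 2-bromophenyl on a carbonyl carbon. Three measured swaps at that carbonyl carbon bear on this change. The two involving 2-bromophenyl are a 2.1-fold higher number from compound 1 to compound 2 (0.32 log units; beyond the scatter) and a 1.4-fold lower number from compound 2 to compound 3 (0.14 log units; within the scatter), and the remaining one is a 1.5-fold higher number from compound 1 to compound 3 (0.18 log units; within the scatter). For the measured compounds named here, no measured compound carries 3-fluorophenyl, so the expectation rests on these steps alone. A small move to a lower number in this assay is expected, not clearly beyond the scatter. The estimated change is a 1.5-fold lower number from compound 2 to compound 4 (0.17 log units; within the scatter). For compound 4 the estimated value is 170 nM, with an expected range of 85 nM to 340 nM.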

Compound 4, half-maximal inhibitory concentration: 170 nM
Compound 4: the middle estimate sits on the measured number at the digits printed; the range from low to high includes it.
By their numbers in this assay, from the lowest: compounds 1, 4, 3 and 2 (each within the scatter of the next, the first and the last beyond it).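

In this assay there is a 1.5-fold lower number from compound 2 to compound 4 (0.17 log units; within the scatter) and a 1.1-fold lower number from compound 3 to compound 4 (0.02 log units; within the scatter) and a 1.4-fold higher number from compound 1 to compound 4 (0.15 log units; within the scatter) and all three lie within the scatter. A fluorine-bearing phenyl on this carbonyl carbon therefore sits with the 2-bromophenyl, 4-chlorophenyl and 3-methoxyphenyl groups, and it closes no gap beyond what compound 1 and compound 2 already show. No measurement on hand accounts for these numbers. From the compounds shown here alone, whether this carbonyl carbon accepts anything other than a substituted phenyl, such as an amine, a carboxylic acid or a longer alkyl chain, stays open.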